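Nitro in Place of Hydrogen on the Furan of Compound 2

A few compounds are considered here, and "the series" means these few. Any claim that something is new, unique, unknown or untested is made for them only; others in the source may bear on it.

Of the compounds shown here, two have been measured in a functional assay on the whole organism (strain Wistar Albino) for inhibition, with Rattus norvegicus as the target, read by paw edema, with a stated time of 4 h, at a dose of 20 mg/kg; a higher number here means more inhibition at the dose given (going by the name of the read-out), a lower number less inhibition. Compound 1 `COc1ccc2[nH]c(C)c(Cc3nn4c(-c5ccoc5C)nnc4s3)c2c1` gives 31.2%, and compound 2 `COc1ccc(Cl)c(-c2nnc3n2NC(c2ccco2)S3)c1` gives 25.6%; the two numbers lie within the usual scatter of each other, so neither stands apart. Compound 3 `COc1ccc(Cl)c(-c2nnc3n2NC(c2ccc([N+](=O)[O-])o2)S3)c1` is not yet measured. It differs from compound 2 by nitro in place of hydrogen on an aromatic carbon. Within the data shown here, no step between measured compounds is available to guide the change. In this assay compound 3 is therefore expected to give 28%, between 15% and 42%. The step of a number 2.4 percentage points higher from compound 2 to compound 3 (within the scatter) is expected to stay within the scatter.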

Compound 3, a percentage reported as inhibition, in the whole organism at one dose (the size of the read-out at that dose, not a potency): 24.2%
The estimate for compound 3 lay 3.8 percentage points above the measured number; measured number inside the range.
By their numbers in this assay, from the lowest: compounds 3, 2 and 1 (each within the scatter of the next).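

The change from furan-2-yl to 5-nitrofuran-2-yl comes out in this assay as a number 1.4 percentage points lower from compound 2 to compound 3 (within the scatter). On this aromatic carbon next to the ring oxygen, nitro in place of hydrogen therefore gives no difference beyond the scatter at this dose. Nothing measured here speaks to what lies behind this step.

From the compounds shown here alone, whether an amine or a carboxylic acid at this same place would also stay within the scatter remains open. So does whether nitro would give the same result at another dose or read-out time.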